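Capping the Indole Nitrogen with Methyl

This account rests on a few compounds, and the source may have more. Where it says the series, first, only, none or still open, it means among the compounds named here.

Among the compounds with values here, compound 1 `COc1cc(-c2ccnc3cc(-c4ccc5cc[nH]c5c4)nn23)cc(OC)c1OC` is the one compound here with a full number in a functional assay on A549 cells (Homo sapiens) for inhibition, read by CCK-8 assay, with a stated time of 48 h; a higher number here means a weaker inhibitor, a lower number a stronger inhibitor: compound 1 gives 170 nM. Compound 2 `COc1cc(-c2ccnc3c(-c4ccc(C)cc4)cnn23)cc(OC)c1OC` reaches only a limit of this assay, giving > 10000 nM, which is the limit of > 10000 nM in this assay, at which 1 of the 2 values shown sits. Compound 3 `COc1cc(-c2ccnc3cc(-c4ccc5ccn(C)c5c4)nn23)cc(OC)c1OC` differs from compound 1 at a single place: methyl in place of hydrogen on an aromatic nitrogen. Within the data shown here, no measured pair shows this change, so its effect is unknown; a step of modest size toward weaker inhibition is expected, a 2.4-fold higher number from compound 1 to compound 3 (0.37 log units; beyond the scatter). Compound 3 is therefore estimated to give 400 nM, with a likely range from 150 nM to 1500 nM.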

Compound 3, half-maximal inhibitory concentration: 829 nM
Compound 3: middle estimate off by 2.1-fold (0.32 log units), on the low side; measured number inside the range.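

Going from 1H-indol-6-yl to 1-methyl-1H-indol-6-yl gives a 4.9-fold higher number from compound 1 to compound 3 (0.69 log units; beyond the scatter) in this assay and so weakens inhibition. The hydrogen on this aromatic nitrogen therefore matters to the number, since a single added carbon is enough to shift it, although compound 3 still gives a full value rather than a limit. Nothing measured here gives a reason for this step. Open, as far as these compounds go, is how an ethyl group, a longer chain or a chain ending in an amine would behave on this nitrogen, and whether a carboxylic acid there would be tolerated.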